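The source may report more compounds than this note shows. Statements on the series, on what has been measured and on what is new or still open speak of the compounds shown alone.

Measured compounds in a functional assay on U-87MG ATCC cells for cytotoxicity against U-87 MG (Homo sapiens), read by colorimetric assay and MTT assay; on this read-out higher numbers stand for weaker inhibition and lower numbers for stronger inhibition:
compound 1, `COc1ccc(-c2cc3c(OC)cc(OC)cc3n(CC#N)c2=O)cc1`, 10000 nM;
compound 2, `COc1ccc(-c2cc3c(OC)cc(OC)cc3n(CC(=O)OCc3ccccc3)c2=O)cc1`, 10000 nM;
compound 3, `COc1ccc(-c2cc3c(OC)cc(OC)cc3n(CCC#N)c2=O)cc1`, 10000 nM.

The step of no change at the digits printed from compound 1 to compound 2 (within the scatter) covers the change (benzyloxycarbonyl in place of cyano on a saturated chain carbon bound to an aromatic nitrogen). The core of compound 3 differs from the core of compound 1 by cyanomethyl in place of cyano on a saturated chain carbon bound to an aromatic nitrogen. Compound 4, `COc1ccc(-c2cc3c(OC)cc(OC)cc3n(CCC(=O)OCc3ccccc3)c2=O)cc1`, is not yet measured in this assay; it differs from compound 3 by benzyloxycarbonyl in place of cyano on a saturated chain carbon, two bonds along the chain from an aromatic nitrogen. Within the data shown here, this is the same kind of change as the one from compound 1 to compound 2, not the same: there the place is on a saturated chain carbon bound to an aromatic nitrogen, here it is on a saturated chain carbon two bonds along the chain from an aromatic nitrogen. All three measured values in this assay sit level, and the step of no change at the digits printed from compound 2 to compound 3 (within the scatter) likewise shows no movement. The expected step of no change at the digits printed from compound 3 to compound 4 (within the scatter) is set beside the earlier one, resting on no change at the digits printed from compound 1 to compound 2 (within the scatter). Compound 4 is expected at 10000 nM, with a range from 5000 nM to 20000 nM.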

Compound 4, half-maximal inhibitory concentration: 10000 nM
For compound 4 middle estimate and measured number coincide at the digits printed; low and high end bracket the measured number.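

In this assay the new steps read no change at the digits printed from compound 3 to compound 4 (within the scatter), no change at the digits printed from compound 2 to compound 4 (within the scatter) and no change at the digits printed from compound 1 to compound 4 (within the scatter). Benzyloxycarbonyl in place of cyano gives the same result on both cores: the same change on two cores in this assay, no change at the digits printed (within the scatter) from compound 1 to compound 2 and no change at the digits printed (within the scatter) from compound 3 to compound 4, 1.0-fold (0.00 log units) apart, within the scatter of two such steps
This is agreement between two steps that show no movement, so it does not show that the change would carry over in the same way on a core where it shifted the value. Open, from the compounds shown here alone, is whether any group on this chain moves the value at all; an amine or a carboxylic acid in place of the cyano or the benzyloxycarbonyl would test that.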